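The compounds below may be only part of what the source reports. "The series", "measured", "known", "first", "only" and "open" are said of these compounds alone.

Measured so far in an assay on CHO cells for antagonist activity at transient receptor potential cation channel subfamily V member 1 (Homo sapiens), read by FLIPR; on this read-out lower numbers stand for stronger inhibition and higher numbers for weaker inhibition: compound 1 `CCCOc1cc(C(F)(F)F)ccc1CNC(=O)C(C)c1ccc(NS(C)(=O)=O)c(F)c1` gives 2 nM; compound 2 `CC(C(=O)NCc1ccc(C(F)(F)F)cc1OCc1ccc(F)cc1)c1ccc(NS(C)(=O)=O)c(F)c1` gives 0.5 nM.

Compound 2 holds the lowest of the two numbers, its nearest neighbour being compound 1, which lies a step away that is beyond the scatter. Compound 3 `CCCCCCSc1cc(C(F)(F)F)ccc1CNC(=O)C(C)c1ccc(NS(C)(=O)=O)c(F)c1` differs from compound 2 in one place: hexylsulfanyl in place of (4-fluorobenzyl)oxy on an aromatic carbon. Among the measured compounds shown here, the only measured step that bears on this change is a 4.0-fold lower number from compound 1 to compound 2 (0.60 log units; beyond the scatter), where 4-fluorophenyl replaced ethyl on a saturated chain carbon bound to an oxygen on an aromatic ring; compound 3 gives that ring up again for a chain, so a modest move back toward the number of compound 1 is expected. Compound 3 is therefore estimated at 1.5 nM in this assay, between 0.4 nM and 6 nM, which would mean a 3.0-fold higher number from compound 2 to compound 3 (0.48 log units; beyond the scatter).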

Compound 3, inhibition constant: 1.8 nM
Beside the measured number, compound 3's estimate is 1.2-fold (0.08 log units) below it; measured number inside the range.
By their numbers in this assay, from the lowest: compound 2; then compounds 3 and 1 (each within the scatter of the next).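

In this assay, hexylsulfanyl on this aromatic carbon does not keep up with (4-fluorobenzyl)oxy, giving a 3.6-fold higher number from compound 2 to compound 3 (0.56 log units; beyond the scatter). Against propoxy the change gives a 1.1-fold lower number from compound 1 to compound 3 (0.05 log units; within the scatter), so these two ringless chains are not told apart here, even though one is longer and carries sulfur in place of oxygen. No measurement at hand accounts for either step. Chain length and the sulfur change together in these compounds, so their separate contributions remain open. Also open, from the compounds shown here alone, is how a benzylsulfanyl group or an amine would read on this carbon.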